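A Thiophene Urea Steps Off the Bromophenyl Series

A few compounds are considered here, and "the series" means these few. Any claim that something is new, unique, unknown or untested is made for them only; others in the source may bear on it.

Within the data shown here, compound 2 `O=C(Nc1ccc(Br)cc1)Nc1ccc(Nc2ncnc3c2OCCN3)cc1` carries a bromophenyl urea on the shared core; in an assay on isolated protein for inhibition of proto-oncogene tyrosine-protein kinase receptor Ret variant V804M (Homo sapiens), read by 33P incorporation, with stated times of 15 min and 40 min (on this read-out higher numbers stand for weaker inhibition and lower numbers for stronger inhibition), compound 2 gives 2350 nM, and the two other numbers known so far lie within the scatter of it. Compound 1 `O=C(Nc1ccc(Cl)cc1)Nc1ccc(Nc2ncnc3c2OCCN3)cc1` gives 2280 nM, and compound 3 `O=C(Nc1ccc(Nc2ncnc3c2OCCN3)cc1)Nc1cc(Cl)cc(Cl)c1` gives 1300 nM. Compound 4 `O=C(Nc1ccc(Nc2ncnc3c2OCCN3)cc1)Nc1cccs1` differs from compound 2 only by thiophen-2-yl in place of 4-bromophenyl on an amide-type nitrogen. Two earlier steps change the same aryl group on the amide-type nitrogen: a 1.8-fold lower number from compound 1 to compound 3 (0.24 log units; within the scatter) and a 1.8-fold lower number from compound 2 to compound 3 (0.26 log units; within the scatter), both within the scatter, as is a 1.0-fold higher number from compound 1 to compound 2 (0.01 log units; within the scatter). No measured change has yet moved this assay beyond its scatter, so for compound 4 a step of about a 1.3-fold higher number from compound 2 to compound 4 (0.11 log units; within the scatter) is expected, without a firm direction. Compound 4 is therefore estimated at 3000 nM, between 1200 nM and 8000 nM.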

Compound 4, half-maximal inhibitory concentration: 8640 nM
Beside the measured number, compound 4's estimate is 2.9-fold (0.46 log units) below it; measured number above the stated range.
By their numbers in this assay, from the lowest: compounds 3, 1 and 2 (each within the scatter of the next); then compound 4.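

In this assay, among these compounds, thiophen-2-yl on the amide-type nitrogen brings the first change at this position to lie beyond the scatter (a 3.7-fold higher number from compound 2 to compound 4 (0.57 log units; beyond the scatter); a 3.8-fold higher number from compound 1 to compound 4 (0.58 log units; beyond the scatter); a 6.6-fold higher number from compound 3 to compound 4 (0.82 log units; beyond the scatter)). Compounds 1, 2 and 3 stay within the scatter of each other, yet compound 4 stands apart from all three, so the group on this nitrogen can move the number after all. Nothing measured here bears on why this happens. Whether the higher number belongs to thiophen-2-yl alone stays open, since furan-2-yl and thiophen-3-yl do not appear among these compounds. Unsubstituted phenyl is also absent, so the part played by the bromine or chlorine atoms cannot be separated from that of the ring.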